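The compounds below may be only part of what the source reports. "The series", "measured", "known", "first", "only" and "open" are said of these compounds alone.

Measured so far in a functional assay on HCT-116 cells (Homo sapiens) for inhibition, read by MTT assay, with a stated time of 48 h; on this read-out lower numbers stand for stronger inhibition and higher numbers for weaker inhibition:
compound 1 `COc1ccc(CNc2cc(OC)c(OC)c(OC)c2)cc1Cl` gives 41700 nM
compound 2 `C/C=C/C(=O)N(Cc1ccc(OC)c(O)c1)c1cc(OC)c(OC)c(OC)c1` gives 55 nM
compound 3 `C/C=C/C(=O)N(Cc1ccc(OC)c(F)c1)c1cc(OC)c(OC)c(OC)c1` gives 1160 nM

Of these three numbers, compound 3 holds the middle one, above that of compound 2 and below that of compound 1. Next comes compound 4 `C/C=C/C(=O)N(Cc1ccc(OC)c(Cl)c1)c1cc(OC)c(OC)c(OC)c1` with chloro in place of fluoro on an aromatic carbon, ortho to a methoxy group and meta to a large group (chloro in place of fluoro on an aromatic carbon).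

Within the data shown here, the one measured step on that carbon (a 21-fold higher number from compound 2 to compound 3 (1.32 log units; beyond the scatter)) is large, but it removes hydroxy and so sets no size for an exchange of fluoro for chloro. Among the measured compounds shown here, no measured pair shows that exchange. Compound 4 shares the 3-chloro-4-methoxyphenyl group with compound 1, but the two differ elsewhere, so that value is no direct guide.

The starting point is therefore compound 3 at 1160 nM with little expected movement. Expected in this assay is no step clearly beyond the scatter, with a slight lean to a higher number (a 1.3-fold higher number from compound 3 to compound 4 (0.11 log units; within the scatter)). For compound 4 the estimated value is 1500 nM with 400 nM to 6000 nM as its expected range.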

Compound 4, half-maximal inhibitory concentration: 1420 nM
Beside the measured number, compound 4's estimate is 1.1-fold (0.02 log units) above it; the measured number falls inside the stated range.
By their numbers in this assay, from the lowest: compound 2; then compounds 3 and 4 (each within the scatter of the next); then compound 1.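

In this assay there is a 1.2-fold higher number from compound 3 to compound 4 (0.09 log units; within the scatter) and so chloro and fluoro are not told apart on this aromatic carbon. Leaving hydroxy now has two readings, as a 26-fold higher number from compound 2 to compound 4 (1.41 log units; beyond the scatter) is large, like a 21-fold higher number from compound 2 to compound 3 (1.32 log units; beyond the scatter) before it, so the large step away from hydroxy is not tied to fluoro alone. Among these compounds, the 3-chloro-4-methoxyphenyl group also gives the first pair that isolates the group on the nitrogen, with a 29-fold lower number from compound 1 to compound 4 (1.47 log units; beyond the scatter) for (prop-1-en-1-yl)carbonyl in place of hydrogen.

Nothing available explains the size of any of these steps. Open, on these data alone, is whether an amine or a hydroxymethyl group on this carbon would come close to compound 2 at 55 nM in this assay or stay with the two halogens, and whether an acetyl group on the nitrogen would serve as (prop-1-en-1-yl)carbonyl does.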